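A few compounds are considered here, and "the series" means these few. Any claim that something is new, unique, unknown or untested is made for them only; others in the source may bear on it.

In an ADME assay on HEK293 cells (Homo sapiens) for cytotoxicity, read by MTT assay, with a stated time of 24 h (a lower number here means a stronger inhibitor, a higher number a weaker inhibitor), compound 1 (`CN(C)CCCNc1nc2cc([N+](=O)[O-])ccc2nc1NCc1ccccc1`) gives 2.74 ug/mL against 10.7 ug/mL for compound 2 (`CN(C)CCCNc1nc2cc([N+](=O)[O-])ccc2nc1NCc1ccc(Cl)cc1`), while compound 3 (`COc1ccc(CNc2nc3ccc([N+](=O)[O-])cc3nc2NCCCN(C)C)cc1`) gives 38.6 ug/mL as the highest number of the three. Compound 4 (`CN(C)CCCNc1nc2cc([N+](=O)[O-])ccc2nc1NCc1ccccc1C(F)(F)F`) differs from compound 3 by one change (2-(trifluoromethyl)phenyl in place of 4-methoxyphenyl on a saturated chain carbon bound to a nitrogen on an aromatic ring): 2-(trifluoromethyl)phenyl in place of 4-methoxyphenyl on a saturated chain carbon bound to a nitrogen on an aromatic ring. Going by the values given here, no measured step covers this group. Both ring-substituted compounds sit higher than compound 1 (a 3.9-fold higher number from compound 1 to compound 2 (0.59 log units; beyond the scatter) and a 14-fold higher number from compound 1 to compound 3 (1.15 log units; beyond the scatter)), and methoxy in place of chloro gave a modest rise (a 3.6-fold higher number from compound 2 to compound 3 (0.56 log units; beyond the scatter)). Losing the methoxy group for a halogen-bearing group is therefore expected to give a modest fall in this assay (a 3.2-fold lower number from compound 3 to compound 4 (0.51 log units; beyond the scatter)). The estimate for compound 4 is 12 ug/mL with 3 ug/mL to 45 ug/mL as its expected range.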

Compound 4, half-maximal inhibitory concentration: 24.7 ug/mL
For compound 4 the middle estimate is 2.1-fold (0.31 log units) below the measured one; the measured number falls inside the stated range.
By their numbers in this assay, from the lowest: compound 1; then compound 2; then compounds 4 and 3 (each within the scatter of the next).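

In this assay, 2-(trifluoromethyl)phenyl in place of 4-methoxyphenyl leaves the number within the scatter (a 1.6-fold lower number from compound 3 to compound 4 (0.19 log units; within the scatter)), so these two different ring substitutions do not separate here. A halogen-bearing group alone therefore does not bring the number back to that of the 4-chlorophenyl compound (a 2.3-fold higher number from compound 2 to compound 4 (0.36 log units; beyond the scatter)), and all three substituted compounds stay above the unsubstituted one (a 9.0-fold higher number from compound 1 to compound 4 (0.95 log units; beyond the scatter)). No available measurement explains these steps.

The change alters both the substituent and its place on the ring, and these remain unseparated. From the compounds shown here alone, a 4-(trifluoromethyl)phenyl group would address that, while an amine on the ring remains untested territory.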